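This account rests on a few compounds, and the source may have more. Where it says the series, first, only, none or still open, it means among the compounds named here.

Compound 1, `Cc1cc(Nc2cc(Cl)cc(S(F)(F)(F)(F)F)c2)nc(N)n1`, in an assay on cells for inhibition of S-adenosylmethionine decarboxylase proenzyme (Homo sapiens), read by mass spectrometry, at pH 7.2 (on this read-out lower numbers stand for stronger inhibition and higher numbers for weaker inhibition), gives > 180000 nM, which is a limit of the assay rather than a number.
Compound 2, `Cc1cc(Nc2cccc(S(F)(F)(F)(F)F)c2)nc(N)n1`, in this assay gives > 180000 nM, again a limit.
Compound 3, `Cc1cc(Nc2cccc(Cl)c2)nc(N)n1`, in this assay gives > 180000 nM, also a limit.

All three values sit at the limit of > 180000 nM in this assay, at which 3 of the 3 values shown sit, so none of the steps among these compounds can be read. From compound 2 to compound 1 the change is chloro in place of hydrogen on an aromatic carbon, and the step is a step that the two limits leave unreadable from compound 2 to compound 1. The same kind of change leads from compound 3 to compound 4, `Cc1cc(Nc2cccc(Cl)c2Cl)nc(N)n1`, namely (chloro in place of hydrogen on an aromatic carbon). The cores of compound 2 and compound 3 differ by one chlorine atom in place of a group of 6 heavy atoms (5 fluorine, 1 sulfur; no ring), on an aromatic carbon. Because compound 1 and compound 3 both sit at the limit of > 180000 nM in this assay, at which 3 of the 3 values shown sit, the step from compound 3 to compound 4 in this assay is expected to be a step that the limit leaves unreadable from compound 3 to compound 4, with no readable size to rest on. Compound 4 is therefore estimated at 250000 nM, between 100000 nM and 1000000 nM, most likely reported again only as a limit.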

Compound 4, half-maximal inhibitory concentration: > 180000 nM
Compound 4 ended at the assay's limit; the forecaster's own chance of this, stated with the estimate: 85%; the middle value is on the limit's open side.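

No new step can be read from compound 3 to compound 4, because in this assay both compounds give only a limit of the assay rather than a number: the limit of > 180000 nM in this assay, at which 4 of the 4 values shown sit. The compounds shown leave open whether any change to the shared core would give a readable value in this assay at all.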